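A few compounds are considered here, and "the series" means these few. Any claim that something is new, unique, unknown or untested is made for them only; others in the source may bear on it.

Measured compounds, values in a functional assay on MCF7 cells (Homo sapiens) for cytotoxicity, read by MTT assay, with a stated time of 48 h; on this read-out higher numbers stand for weaker inhibition and lower numbers for stronger inhibition:
compound 1, `CCCCCCCCNC(=O)[C@@H](NC(=O)c1ccccc1)[C@@H](C)O` — 111000 nM
compound 2, `CCCCCCCCCCCCNC(=O)[C@@H](NC(=O)c1ccccc1)[C@@H](C)O` — 36600 nM
compound 3, `CCCCCCCCCCCCNC(=O)[C@@H](NC(=O)c1cc2ccccc2o1)[C@@H](C)O` — 20900 nM

Compound 2 stands second highest of the three numbers in this assay. Its nearest neighbour is compound 3, reached by a 1.8-fold lower number from compound 2 to compound 3 (0.24 log units; within the scatter), a step within the scatter. Its furthest is compound 1: the step of a 3.0-fold lower number from compound 1 to compound 2 (0.48 log units; beyond the scatter) is the only one in the set that lies beyond the scatter, and it concerns the chain, not the acyl group.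

Compound 4, `CCCCCCCCCCCCNC(=O)[C@@H](NS(=O)(=O)c1ccc(C)cc1)[C@@H](C)O`, differs from compound 2 by (4-methylphenyl)sulfonyl in place of benzoyl on an amine nitrogen. For the measured compounds named here, the only measured step that bears on a change at this nitrogen is a 1.8-fold lower number from compound 2 to compound 3 (0.24 log units; within the scatter), which exchanged one aromatic group for another on the carbonyl carbon and moved the number by less than the scatter. Going by the values given here, no measured step exchanges an amide for a sulfonamide, so the expectation rests on that single nearby comparison and is loose.

Compound 4 is therefore expected to give 35000 nM in this assay, with a range of 12000 nM to 110000 nM. The expected step from compound 2 is a 1.0-fold lower number from compound 2 to compound 4 (0.02 log units; within the scatter), no change beyond the scatter.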

Compound 4, half-maximal inhibitory concentration: 31100 nM
Estimate against measurement, compound 4: 1.1-fold (0.05 log units) above, within the range that was stated.
By their numbers in this assay, from the lowest: compounds 3, 4 and 2 (each within the scatter of the next); then compound 1.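

At the amine nitrogen of the shared core, the series now holds a sulfonyl-linked group as well as carbonyl-linked ones: in this assay, (4-methylphenyl)sulfonyl in place of benzoyl gives a 1.2-fold lower number from compound 2 to compound 4 (0.07 log units; within the scatter). Compound 2 and compound 3 had only shown an exchange of the aromatic group on the carbonyl carbon, whereas this step replaces the carbonyl link itself and still stays within the scatter. No measurement at hand offers an explanation for this result.

For the compounds shown here, whether the sulfonyl link behaves the same way with the chain of compound 1 remains open, since the only step for this exchange carries the chain of compound 2. Also open, on these data alone, is how a free amine or a methanesulfonyl group on this nitrogen would read in this assay.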